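The source may hold more compounds than are shown below. What is called first, only, known or untested is meant among the compounds shown, and "the series" means these compounds.

In a functional assay on SMMC-7721 cells (Homo sapiens) for cytotoxicity, read by MTT assay, with a stated time of 72 h (a lower number here means a stronger inhibitor, a higher number a weaker inhibitor), compound 1 `O=C1C(=Cc2ccc(Cl)cc2)C(=O)N(c2ccc(Cl)cc2)N1c1ccc(Cl)cc1` gives 30900 nM as its read-out. Compound 2 `COc1ccc(C=C2C(=O)N(c3ccc(Cl)cc3)N(c3ccc(Cl)cc3)C2=O)cc1` gives > 128000 nM in this assay as a limit of the assay and not a number. Its only mark on the scale is the limit of > 128000 nM in this assay, at which 1 of the 2 values shown sits, and it has no exact place there.

The change from compound 2 to compound 3 `COc1cccc(C=C2C(=O)N(c3ccc(Cl)cc3)N(c3ccc(Cl)cc3)C2=O)c1OC` is 2,3-dimethoxyphenyl in place of 4-methoxyphenyl on a double-bonded chain carbon bound to a double-bonded ring carbon and so 2,3-dimethoxyphenyl stands in place of 4-methoxyphenyl on a double-bonded chain carbon bound to a double-bonded ring carbon. Among the measured compounds shown here, only one measured step bears on this, and only indirectly. It is an at least 4.1-fold higher number from compound 1 to compound 2 (0.61 log units; beyond the scatter) with methoxy in place of chloro on an aromatic carbon, and its true size is open on one side. Compound 3 keeps methoxy on that ring and regains no chloro, so the step of an at least 4.1-fold higher number from compound 1 to compound 2 (0.61 log units; beyond the scatter) gives no reason to expect a return towards compound 1. No step beyond the scatter is expected in this assay, and a second limit is quite likely. For compound 3 the estimated value is 120000 nM as the middle of an expected range from 40000 nM to 250000 nM in all. The estimate amounts to an expected at least 1.0-fold lower number from compound 2 to compound 3 (0.02 log units; that floor lies within the scatter) in this comparison.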

Compound 3, half-maximal inhibitory concentration: 14100 nM
Beside the measured number, compound 3's estimate is 8.5-fold (0.93 log units) above it, and the stated range ends above it.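

In this assay, from the compounds shown here alone, 2,3-dimethoxyphenyl in place of 4-methoxyphenyl on a double-bonded chain carbon bound to a double-bonded ring carbon brings the read-out onto the measurable scale, with an at least 9.0-fold lower number from compound 2 to compound 3 (0.95 log units; beyond the scatter), and the full size of this step stays open on one side. Compound 2 has only a limit of the assay and not a number: the limit of > 128000 nM in this assay, at which 1 of the 3 values shown sits. Methoxy on this ring therefore does not by itself leave a compound at a limit, as the first step alone might have suggested, and 2,3-dimethoxyphenyl also goes past 4-chlorophenyl, with a 2.2-fold lower number from compound 1 to compound 3 (0.34 log units; beyond the scatter), which makes compound 3 the strongest inhibitor of the three in this assay.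

Which feature of the change carries the step stays open, since 2,3-dimethoxyphenyl differs from 4-methoxyphenyl in both the number and the placing of its methoxy groups, and the compounds shown do not separate the two. Also open, going by these compounds, is how this read-out would respond to an amine or a carboxylic acid on that ring in place of methoxy.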